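Naphthalenyl to Indolyl on a Cytotoxic Biaryl Amide

A few compounds are considered here, and "the series" means these few. Any claim that something is new, unique, unknown or untested is made for them only; others in the source may bear on it.

Compound 1 `CC(C)N(Cc1cccc(OCCCCCC(=O)O)c1)C(=O)c1ccc(-c2cccc3ccccc23)cc1`: < 1.3 nM
Compound 2 `CC(C)N(Cc1cccc(OCCCCCC(=O)O)c1)C(=O)c1ccc(-c2cccc(-c3ccccc3)c2)cc1`: > 26000 nM
Compound 3 `CC(C)N(Cc1cccc(OCCCCCC(=O)O)c1)C(=O)c1ccc(-c2ccoc2)cc1`: > 26000 nM

In an ADME assay on BJ cells (Homo sapiens) for cytotoxicity, read by CellTiter-Glo and resazurin assay, with a stated time of 72 h (on this read-out higher numbers stand for an effect only at larger amounts of compound and lower numbers for an effect already at smaller amounts), compound 1 is known only as a limit, < 1.3 nM, so its place among the three values is the lower edge of the assay, as recorded in the limit of < 1.3 nM in this assay, at which 1 of the 3 values shown sits. Compound 2 likewise gives only a limit, > 26000 nM. Compound 3 also sits at a limit, > 26000 nM, the upper edge described in the limit of > 26000 nM in this assay, at which 2 of the 3 values shown sit. Both measured steps start from compound 1: an at least 20000-fold higher number from compound 1 to compound 2 (4.30 log units; beyond the scatter) and an at least 20000-fold higher number from compound 1 to compound 3 (4.30 log units; beyond the scatter). Each lies beyond the scatter and each runs the same way, from an effect at the smallest amounts to none found at the largest. The step between compound 2 and compound 3 cannot be read, a step that the two limits leave unreadable from compound 2 to compound 3.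

Compound 4 `CC(C)N(Cc1cccc(OCCCCCC(=O)O)c1)C(=O)c1ccc(-c2ccc3cc[nH]c3c2)cc1` has not yet been measured. It differs from compound 1 in one place: 1H-indol-6-yl in place of naphthalen-1-yl on an aromatic carbon. The two measured steps exchanged the naphthalen-1-yl for groups with a different ring count and each removed the effect; the entering 1H-indol-6-yl still brings two aromatic rings, so a smaller rise than those steps is expected. Compound 4 is therefore expected to give about 1000 nM, within a range from 30 nM to 30000 nM. The expected step is an at least 760-fold higher number from compound 1 to compound 4 (2.88 log units; beyond the scatter).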

Compound 4, half-maximal effective concentration: > 26000 nM
Compound 4: no number, only a limit; the forecaster's own chance of this, stated with the estimate: 45%; middle value at least 26-fold (1.41 log units) from the limit.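

In this assay, among the compounds shown here, the exchange gives an at least 20000-fold higher number from compound 1 to compound 4 (4.30 log units; beyond the scatter), which shows that two aromatic rings on this aromatic carbon, para to a large group, are not enough to keep the effect of compound 1; the earlier steps had all changed the ring count, so they could not show this. The change also replaces a six-membered aromatic ring of carbon only with a five-membered aromatic ring with 1 hetero atom, brings in a hydrogen-bond donor and alters the point of attachment, and these compounds cannot separate those differences. Naphthalen-1-yl remains the only one of the four groups here that gives an effect at the smallest amounts, while the steps among compound 2, compound 3 and compound 4 cannot be read, as all three sit at the same limit: the limit of > 26000 nM in this assay, at which 3 of the 4 values shown sit.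

As far as these compounds go, whether the effect follows the naphthalene itself or its point of attachment remains open, and naphthalen-2-yl or 1H-indol-4-yl at this place would bear on that question. From the compounds shown here alone, compound 1 is itself only a limit, < 1.3 nM, so the full size of its effect also remains open.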